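Quinoline carboxamides: methyl to cyano on the fused ring

The compounds below may be only part of what the source reports. "The series", "measured", "known", "first", "only" and "open" are said of these compounds alone.

Measured so far:
compound 1 `COc1ccccc1N1CCN(CCCNc2ncc(C#N)cc2C(=O)N(C)C)CC1` — 20 nM
compound 2 `COc1cc(F)ccc1N1CCN(CCCNc2c(C(=O)N(C)C)cnc3c(C)cccc23)CC1` — 316 nM

In a functional assay on aorta for antagonist activity at Alpha-1D adrenergic receptor (Rattus norvegicus) (on this read-out lower numbers stand for tighter binding and higher numbers for weaker binding), compound 1 gives 20 nM. In this assay compound 2 gives 316 nM, the highest of the two numbers recorded; the gap to compound 1 lies well beyond the usual scatter, but the two compounds differ at several places at once, so the two values alone tell nothing about any single change.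

Compound 3 `COc1cc(F)ccc1N1CCN(CCCNc2c(C(=O)N(C)C)cnc3c(C#N)cccc23)CC1` is not yet measured. It differs from compound 2 in one place: cyano in place of methyl on an aromatic carbon. For the measured compounds named here, no measured pair isolates this change, so its effect must be taken as open. With nothing to anchor it, the step from compound 2 to compound 3 in this assay is expected to be modest, and a 1.6-fold lower number from compound 2 to compound 3 (0.20 log units; within the scatter) is the size assumed here, slightly toward a lower number rather than none at all, with a wide band to either side.

Compound 3 is therefore expected to give about 200 nM in this assay, within roughly 60 nM to 800 nM.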

Compound 3, dissociation constant: 398 nM
Compound 3: the middle estimate sits 2.0-fold (0.30 log units) below what was measured; the range from low to high includes it.
By their numbers in this assay, from the lowest: compound 1; then compounds 2 and 3 (each within the scatter of the next).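

In this assay, for the compounds shown here, cyano in place of methyl on an aromatic carbon, ortho to a fused ring and meta to a fused ring, gives a 1.3-fold higher number from compound 2 to compound 3 (0.10 log units; within the scatter), the first reading of this change. The swap adds one heavy atom and one hydrogen-bond acceptor, yet the step stays within the scatter, so this read-out does not separate methyl from cyano at this carbon on the background shared by compound 2 and compound 3. No supporting data bear on why the step is this small.

Going by these compounds alone, this single pair samples only two groups at this carbon, so it remains open whether the same flat response would hold for a primary amine, a carboxylic acid or a longer chain such as propyl. Also open, as far as these compounds go, is whether cyano in place of methyl would give a step of similar size on another aromatic carbon of the shared core.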